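The source may report more compounds than this note shows. Statements on the series, on what has been measured and on what is new or still open speak of the compounds shown alone.

Compound 1 `CC/C(=N/OC)c1ccc2oc(CSc3nnc(CNc4ccccc4)n3CC)nc2c1` gives in an assay on isolated protein for inhibition of long-chain fatty acid transport protein 1 (Homo sapiens) (a higher number here means a weaker inhibitor, a lower number a stronger inhibitor), only a limit, > 1000 nM. Two further compounds share its core. Compound 2 `CCOC(=O)c1ccc(NC(=O)CSc2nnc(CNc3ccccc3)n2CC)cc1` gives 330 nM in this assay. Compound 3 `CCn1c(CNc2ccccc2)nnc1SCC(=O)Nc1ccc(OC)cc1` gives in this assay only a limit, > 1000 nM. Within the data shown here, the sole measured step, an at least 3.0-fold higher number from compound 2 to compound 3 (0.48 log units; beyond the scatter), is an exchange on an aromatic carbon across a different linker and bears on the present change only loosely. Compound 1 therefore sits at the limit of > 1000 nM in this assay, at which 2 of the 3 values shown sit. Compound 4 `CCn1c(CNc2ccccc2)nnc1SCc1nc2cc(Cl)ccc2o1` carries one chlorine atom in place of a group of 6 heavy atoms (4 carbon, 1 nitrogen, 1 oxygen; no ring), on an aromatic carbon. Among the measured compounds shown here, no measured step covers this exchange, so the expectation is that compound 4 stays near the limit, with a step that the limit leaves unreadable from compound 1 to compound 4. Compound 4 is thus estimated at 1500 nM, within a range from 400 nM to 6000 nM.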

Compound 4, half-maximal inhibitory concentration: > 1000 nM
Compound 4 ended at the assay's limit; the forecaster's own chance of this, stated with the estimate: 60%; the middle value does not contradict the limit.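

In this assay, among these compounds, compound 1 and compound 4 both stand at a limit, so no step between them can be read. The compounds shown leave open whether chloro in place of the group of 6 heavy atoms changes inhibition at all.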